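Longer chain on the succinate oxygen, effect on A549 viability

The compounds below may be only part of what the source reports. "The series", "measured", "known", "first", "only" and "open" are said of these compounds alone.

For the measured compounds named here, compound 2 `CCCCOC(=O)CCC(=O)N1CCN(CCCOc2cc3c(Nc4ccc(F)c(Cl)c4)ncnc3cc2OC)CC1` sits second highest of the three numbers so far in a functional assay on A549 cells (Homo sapiens) for cytotoxicity, read by MTT assay, with a stated time of 24 h, tested at 20 uM (a lower number here means a stronger effect, a higher number a weaker effect of the compound at the concentration tested), where compound 2 gives 86%. Its nearest neighbour is compound 3 `CCCCCCCCCCCCOC(=O)CCC(=O)N1CCN(CCCOc2cc3c(Nc4ccc(F)c(Cl)c4)ncnc3cc2OC)CC1`, which in this assay gives 86.8%, with the step of a number 0.8 percentage points higher from compound 2 to compound 3 (within the scatter). Furthest away is compound 1 `CCOC(=O)CCC(=O)N1CCN(CCCOc2cc3c(Nc4ccc(F)c(Cl)c4)ncnc3cc2OC)CC1`, which in this assay gives 70%; the step of a number 16 percentage points higher from compound 1 to compound 2 (beyond the scatter) is the only one beyond the scatter, and the parallel step a number 16.8 percentage points higher from compound 1 to compound 3 (beyond the scatter) is of the same size.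

Compound 4 `CCCCCCCCCCCCCCOC(=O)CCC(=O)N1CCN(CCCOc2cc3c(Nc4ccc(F)c(Cl)c4)ncnc3cc2OC)CC1` differs from compound 2 by decyl in place of hydrogen on a saturated chain carbon, four bonds along the chain from an oxygen next to a carbonyl group. The step that bears on this most directly is a number 0.8 percentage points higher from compound 2 to compound 3 (within the scatter), where octyl entered at the same place and nothing moved beyond the scatter; the decyl of compound 3 at the two-bond position likewise gave the same number as the butyl of compound 2. Going by the values given here, no step within the measured set therefore points to a change beyond the scatter for compound 4. From compound 2 the expected step is a number 1 percentage points higher from compound 2 to compound 4 (within the scatter). Compound 4 is estimated at 87%, within a range of 77% to 96%.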

Compound 4, a percentage reported as activity, at one concentration (the size of the read-out at that concentration, not a potency): 92.3%
The estimate for compound 4 lay 5.3 percentage points below the measured number; low and high end bracket the measured number.
By their numbers in this assay, from the lowest: compound 1; then compounds 2, 3 and 4 (each within the scatter of the next).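

Decyl at the place four bonds along the chain from an oxygen next to a carbonyl group again moves nothing beyond the scatter in this assay: the result is a number 6.3 percentage points higher from compound 2 to compound 4 (within the scatter), and the neighbouring chain gives a number 5.5 percentage points higher from compound 3 to compound 4 (within the scatter). For the compounds shown here, the only step of compound 4 beyond the scatter starts from the ethyl ester, a number 22.3 percentage points higher from compound 1 to compound 4 (beyond the scatter), so compounds 2, 3 and 4 stand as one group without an order among them, and compound 1 lies apart from it. A shrinking effect of the same change on the longer chains cannot be claimed: the same change on two cores in this assay, a number 16 percentage points higher (beyond the scatter) from compound 1 to compound 2 and a number 5.5 percentage points higher (within the scatter) from compound 3 to compound 4, 10.5 percentage points apart, within the scatter of two such steps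

Open, from the compounds shown here alone, is whether a still longer chain stays level with this group, and how a carboxylic acid or an amine at the chain end would read. Going by these compounds, each read-out comes from one concentration, so potency remains open.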